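Changing the Aryl Ring on a Urea Nitrogen

The compounds below may be only part of what the source reports. "The series", "measured", "known", "first", "only" and "open" are said of these compounds alone.

The compounds here share a urea core that joins an aromatic ring to a cyclohexane ring bearing an oxygen substituent. Compound 1 `O=C(Nc1ccc(I)cc1)N[C@H]1CC[C@H](Oc2ccc(F)cc2)CC1` was tested in a functional assay on CRL2813 cells (Homo sapiens) for cytotoxicity, read by sulforhodamine B assay, with a stated time of 5 days (on this read-out higher numbers stand for weaker inhibition and lower numbers for stronger inhibition), where compound 1 gives 10200 nM. Of the two numbers shown, this is the highest. Compound 3 `O=C(Nc1cccc(C(F)(F)F)c1)N[C@H]1CC[C@H](Oc2ccc(C(F)(F)F)cc2)CC1` gives 460 nM in this assay, the nearest value. Compound 2 `O=C(Nc1cccc(C(F)(F)F)c1)N[C@H]1CC[C@H](O)CC1` gives > 20000 nM, which is a limit of the assay rather than a number, namely (the limit of > 20000 nM in this assay, at which 1 of the 3 values shown sits). Among the measured compounds shown here, the one measured step, an at least 43-fold lower number from compound 2 to compound 3 (1.63 log units; beyond the scatter), concerns the substituent on the oxygen on a saturated carbon, not the aromatic ring on the amide-type nitrogen.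

Compound 4 `O=C(Nc1ccccc1[N+](=O)[O-])N[C@H]1CC[C@H](Oc2ccc(F)cc2)CC1` differs from compound 1 by 2-nitrophenyl in place of 4-iodophenyl on an amide-type nitrogen. For the measured compounds named here, none of the measured steps alters the ring on the amide-type nitrogen, so no measured step bears directly on this change. With nothing in the data pointing either way, no step beyond the scatter is expected, and the estimated step is a 1.2-fold higher number from compound 1 to compound 4 (0.07 log units; within the scatter). Compound 4 is therefore estimated at 12000 nM, within a range from 4000 nM to 30000 nM, with a real chance that only a limit is reported.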

Compound 4, half-maximal inhibitory concentration: 3500 nM
Compound 4: middle estimate off by 3.4-fold (0.54 log units), on the high side; measured number below the stated range.
By their numbers in this assay, from the lowest: compound 3; then compound 4; then compound 1. At a limit, above all of these: compound 2.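

In this assay, placing 2-nitrophenyl where 4-iodophenyl stood on an amide-type nitrogen gives a 2.9-fold lower number from compound 1 to compound 4 (0.46 log units; beyond the scatter), the first measured sign that the aryl ring at this place can change the reading, since the earlier step, an at least 43-fold lower number from compound 2 to compound 3 (1.63 log units; beyond the scatter), concerned only the substituent on the oxygen. The change is modest, and it alters both the group on the ring and where that group sits, so this single step cannot show which of the two matters, only that this part of the molecule is not indifferent to replacement. Nothing measured here accounts for why the 2-nitrophenyl compound gives the lower number.

On these data alone, it remains open how a phenyl ring carrying an amine or a carboxylic acid would behave at this place, and whether moving the nitro group to another ring position would keep, enlarge or remove the step. As far as these compounds go, it is also open whether the same swap would give a similar step when the oxygen carries the 4-(trifluoromethyl)phenyl group of compound 3 instead of the substituent shared by compound 1 and compound 4.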